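The source may report more compounds than this note shows. Statements on the series, on what has been measured and on what is new or still open speak of the compounds shown alone.

In a physicochemical assay for lipophilicity (on this read-out higher numbers stand for higher lipophilicity and lower numbers for lower lipophilicity), three compounds have been measured. Compound 1, with the structure `COC(C)(C)CCCC(C)C/C=C/C(C)=C/C(=O)OC1CCC1`, gives 6.44. Compound 2, with the structure `CCOC(=O)/C=C(C)/C=C/CC(C)CCC(=O)C(C)C`, gives 4.3, and compound 3, with the structure `CC(/C=C/CC(C)CCCC(C)(C)C)=C\C(=O)OC(C)C`, gives 7.56. On these numbers compound 1 stands second highest of the three: compound 3 lies above it and compound 2 lies below it, and both of these gaps are beyond the scatter of repeated measurements.

Compound 4, with the structure `CCCC(=O)/C=C(C)/C=C/CC(C)CCCC(C)(C)OC`, has not yet been measured in this assay. Compared with compound 1 the change is propyl in place of cyclobutyloxy on a carbonyl carbon. Cut one bond further out, the same change reads cyclobutyloxycarbonyl to propylcarbonyl: a group of five heavy atoms that holds one four-membered ring and one hydrogen-bond acceptor leaves, and a chain of three carbons with no ring and no acceptor enters.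

Among the compounds with values here, no pair of measured compounds differs in only this one place, so no measured step shows what to expect. The group that enters counts fewer heavy atoms than the one that leaves, and the expectation is a small downward step, close to the edge of the scatter, as a number 0.44 log units lower from compound 1 to compound 4 (beyond the scatter). For compound 4 the estimate in this assay is 6, within a range from 5.4 to 6.6.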

Compound 4, partition coefficient: 5.61
The estimate for compound 4 lay 0.39 log units above the measured number, and the stated range covers the measured number.
By their numbers in this assay, from the lowest: compound 2; then compound 4; then compound 1; then compound 3.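

Within the data shown here, the exchange of cyclobutyloxy for propyl on a carbonyl carbon gives a number 0.83 log units lower from compound 1 to compound 4 (beyond the scatter) in this assay and is the first step between measured compounds that differ in one place only. It shows that the read-out responds to what this carbonyl carbon carries, even though the rest of the structure stays the same. Among these compounds, the single step changes several counted features at once, namely the number of heavy atoms, the four-membered ring and the hydrogen-bond acceptor, and no measurement here accounts for its direction or size.

The compounds shown leave open which of these features matters, and whether the same exchange would give a similar step on a different core. A cyclobutyl or a propoxy group on the same carbonyl carbon would each differ from compound 1 and compound 4 in one place, so such compounds could help separate the contribution of the ring from that of the oxygen.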